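From propyl to phenyl at one aromatic carbon

The source may hold more compounds than are shown below. What is called first, only, known or untested is meant among the compounds shown, and "the series" means these compounds.

In an ADME assay on LL24 cells (Homo sapiens) for inhibition, read by MTT assay, with a stated time of 24 h (a higher number here means a weaker inhibitor, a lower number a stronger inhibitor), compound 1 `CC(C)c1ccc(C(=O)N/N=C/c2ccc([N+](=O)[O-])o2)cc1` gives > 200000 nM, which is a limit of the assay and not a number. For the measured compounds named here, compound 2 `CCCc1ccc(C(=O)N/N=C/c2ccc([N+](=O)[O-])o2)cc1` gives 89000 nM, the only true number so far. Compound 3 `O=C(N/N=C/c1ccc([N+](=O)[O-])o1)c1ccc(-c2ccccc2)cc1` carries phenyl in place of propyl on an aromatic carbon. Going by the values given here, one measured step bears on this same place: an at least 2.2-fold lower number from compound 1 to compound 2 (0.35 log units; beyond the scatter). From the compounds shown here alone, its full size remains open because compound 1 stands at the limit of > 200000 nM in this assay, at which 1 of the 2 values shown sits. That step also exchanged one open group for another, so it says little about what a ring will do. With compound 2 at 89000 nM as the sole anchor, no step beyond the scatter is expected in this assay, though a move either way remains possible. The expected change is a 1.3-fold lower number from compound 2 to compound 3 (0.10 log units; within the scatter). Compound 3 is estimated at 70000 nM, with an expected range from 20000 nM to 200000 nM.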

Compound 3, half-maximal inhibitory concentration: > 200000 nM
Compound 3 was reported as a limit (the forecaster's own chance of this, stated with the estimate: 20%); middle value at least 2.8-fold (0.45 log units) from the limit.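

In this assay, phenyl in place of propyl on this aromatic carbon gives an at least 2.2-fold higher number from compound 2 to compound 3 (0.35 log units; beyond the scatter), so here a six-membered aromatic ring does not keep the level seen with the open propyl chain, a contrast the earlier exchange between two open groups could not show. From the compounds shown here alone, compound 3 gives > 200000 nM, which is a limit of the assay and not a number, so the full size of this step stays open. The step between the isopropyl and phenyl compounds cannot be read, because both stand at a limit: the limit of > 200000 nM in this assay, at which 2 of the 3 values shown sit.

Compound 2, at 89000 nM, remains the only compound here with a true number, so the compounds shown give no reading of how far this position can move. Going by these compounds, whether a longer chain such as butyl, an amine or a carboxylic acid at this carbon would give a lower number stays open.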